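Sulfonamide switch on a shared benzoxazole-free core

This account rests on a few compounds, and the source may have more. Where it says the series, first, only, none or still open, it means among the compounds named here.

Among the measured compounds shown here, compound 2 `COc1ccc(S(=O)(=O)Nc2ccc3oc(-c4ccccc4)nc3c2)cc1` is one of two compounds measured in an assay on cells for inhibition of HSP60/HSP10 (Homo sapiens), with a stated time of 60 min; a higher number here means a weaker inhibitor, a lower number a stronger inhibitor. In this assay compound 2 gives > 100000 nM, which is a limit of the assay and not a number. Compound 1 `COc1ccccc1S(=O)(=O)Nc1ccc2oc(-c3ccccc3)nc2c1` differs only in the aryl group on the sulfonyl sulfur. In this assay compound 1 gives > 100000 nM, again a limit rather than a number. For the measured compounds named here, the one step with data is a step that the two limits leave unreadable from compound 1 to compound 2, and it stays unreadable, since the limit of > 100000 nM in this assay, at which 2 of the 2 values shown sit, holds both values.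

Compound 3 `O=S(=O)(Nc1ccc2oc(-c3ccccc3)nc2c1)c1ccc(Cl)s1` carries the change (5-chlorothiophen-2-yl in place of 4-methoxyphenyl on a sulfonyl sulfur), a 5-chlorothiophen-2-yl in place of 4-methoxyphenyl on a sulfonyl sulfur whose other neighbour is the sulfonamide nitrogen. Going by the values given here, no measured step bears on this change, and both known values sit at a limit, so there is no basis to expect movement in this assay beyond the scatter. Compound 3 is therefore expected to land near the same limit, with the expected step being a number no higher from compound 2 to compound 3 (the limit leaves the size open). The estimate for compound 3 is 100000 nM, within 30000 nM to 300000 nM.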

Compound 3, half-maximal inhibitory concentration: 70000 nM
For compound 3 the middle estimate is 1.4-fold (0.15 log units) above the measured one, within the range that was stated.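

Compound 3 gives 70000 nM in this assay, the first number rather than a limit among the compounds shown, which makes this place on the sulfonyl sulfur readable for the first time. The change to 5-chlorothiophen-2-yl gives an at least 1.4-fold lower number from compound 2 to compound 3 (0.15 log units; that floor lies within the scatter), and the same group in place of 2-methoxyphenyl gives an at least 1.4-fold lower number from compound 1 to compound 3 (0.15 log units; that floor lies within the scatter). Both steps are only floors, and the step between the two methoxyphenyl compounds still cannot be read, because both of those compounds stop at the assay limit: the limit of > 100000 nM in this assay, at which 2 of the 3 values shown sit.

On these data alone, the true size of either step stays open, as does whether any group at this place can move the number beyond the scatter. Also open, as far as these compounds go, is how a carboxylic acid or an amine on the group at the sulfonyl sulfur, or a plain alkyl chain in its place, would read in this assay.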